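The compounds below may be only part of what the source reports. "The series", "measured", "known", "first", "only" and "open" are said of these compounds alone.

Measured so far in a functional assay on A549 cells (Homo sapiens) for antiproliferative activity, read by sulforhodamine B assay, with a stated time of 72 h; a higher number here means a weaker inhibitor, a lower number a stronger inhibitor:
compound 1 `COc1cc(/C=C2\CN(S(C)(=O)=O)C=CC2=O)cc(OC)c1OC` gives 18700 nM
compound 2 `COc1cc(/C=C2\CN(S(=O)(=O)c3ccccc3)C=CC2=O)cc(OC)c1OC` gives 22400 nM

Compound 2 has a single measured neighbour, and the two sit level (a 1.2-fold higher number from compound 1 to compound 2 (0.08 log units; within the scatter)). Next comes compound 3 `COc1cc(/C=C2\CN(S(=O)(=O)c3ccc(C)cc3)C=CC2=O)cc(OC)c1OC`, which differs from compound 2 by one change on the aromatic ring (methyl in place of hydrogen on an aromatic carbon): phenyl to 4-methylphenyl. Within the data shown here, the only measured step that bears on this is the swap of phenyl for methyl on the sulfonyl sulfur (a 1.2-fold higher number from compound 1 to compound 2 (0.08 log units; within the scatter)), and it stayed within the scatter. Among the measured compounds shown here, no measured compound carries a substituent on that ring, so the change itself is untested. No step beyond the scatter is therefore expected in this assay, and no direction is favoured. The estimated step is negligible (a 1.0-fold lower number from compound 2 to compound 3 (0.01 log units; within the scatter)). Compound 3 is expected at 22000 nM (estimated range 10000 nM to 48000 nM).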

Compound 3, half-maximal inhibitory concentration: 20200 nM
For compound 3 the middle estimate is 1.1-fold (0.04 log units) above the measured one; low and high end bracket the measured number.
By their numbers in this assay, from the lowest: compounds 1, 3 and 2 (each within the scatter of the next).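

In this assay, the first substituent on the aromatic ring of the sulfonyl group, a methyl para to a large group, leaves the number level (a 1.1-fold lower number from compound 2 to compound 3 (0.04 log units; within the scatter)). The 4-methylphenyl group also sits level with the methyl on the sulfonyl sulfur (a 1.1-fold higher number from compound 1 to compound 3 (0.03 log units; within the scatter)), so methyl, phenyl and 4-methylphenyl at this site all lie within the scatter of one another across compounds 1, 2 and 3. No available evidence bears on this flat response.

The compounds shown leave open whether a carboxylic acid, an amine or a longer chain at this place on the ring would move the number beyond the scatter. Every compound shown carries a sulfonyl group, so the effect of an acetyl group in its place also remains open.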